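Ester to Acid: One Change on a Thiophene Scaffold

A few compounds are considered here, and "the series" means these few. Any claim that something is new, unique, unknown or untested is made for them only; others in the source may bear on it.

Compound 1 `COC(=O)c1c(Nc2ccccc2)sc(C(=O)c2ccc(OC)cc2)c1C` is the reference point here. In a functional assay, with a stated time of 150 min, tested at 35 ug/mL (on this read-out lower numbers stand for a weaker effect and higher numbers for a stronger effect at the one concentration tested), compound 1 gives 63%, the highest of the two numbers that have been obtained so far. Its closest measured relative, compound 3 `COC(=O)c1c(Nc2ccccc2)sc(C(=O)c2ccc(C)cc2)c1C`, gives 10.3%, and the single-point step between them, a number 52.7 percentage points lower from compound 1 to compound 3 (beyond the scatter), comes from swapping methyl in place of methoxy on an aromatic carbon. Compound 2 `COC(=O)c1c(Nc2ccc(Cl)cc2)sc(C(=O)c2ccc(OC)cc2)c1C`, which carries a chlorine on the aniline ring, is recorded as "not active" (no number reported) without a number.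

Compound 4 `COc1ccc(C(=O)c2sc(Nc3ccccc3)c(C(=O)O)c2C)cc1` is the next compound to be tested. Relative to compound 1 the change is hydrogen in place of methyl on an oxygen next to a carbonyl group. Within the data shown here, no measured step touches this part of the molecule: the only step available concerns a group on the other aromatic ring, and it was large. The expectation for compound 4 therefore rests on the value of compound 1 alone, with wide uncertainty, and the step is estimated as a number 23 percentage points lower from compound 1 to compound 4 (beyond the scatter). Compound 4 is thus estimated at 40%, within a range from 5% to 75%.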

Compound 4, a percentage reported as activity, at one concentration (the size of the read-out at that concentration, not a potency): 61.2%
Beside the measured number, compound 4's estimate is 21.2 percentage points below it, and the stated range covers the measured number.
By their numbers in this assay, from the lowest: compound 3; then compounds 4 and 1 (each within the scatter of the next).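

Replacing methyl with hydrogen on an oxygen next to a carbonyl group turns the methoxycarbonyl into a carboxy group, and in this assay this gives a number 1.8 percentage points lower from compound 1 to compound 4 (within the scatter). Among these compounds, the two compounds therefore cannot be told apart on this read-out, so this change, unlike the one earlier step, a number 52.7 percentage points lower from compound 1 to compound 3 (beyond the scatter), leaves the result inside the usual spread of repeat measurements. Nothing measured here explains why the read-out holds across this change.

Going by these compounds, whether the same holds for other groups at this place, such as a primary amide, an ethyl ester or a longer chain ester, remains open. Also open, on these data alone, is whether the carboxy form would respond as the ester compounds do to a methyl in place of methoxy or to a chlorine on the aniline ring.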